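The compounds below may be only part of what the source reports. "The series", "measured", "known", "first", "only" and "open" are said of these compounds alone.

Compound 1, `COc1cccc(NC(=S)NC2CC(C)(C)Oc3ccc(Br)cc32)c1`, sits at the weak end of the three numbers gathered so far: in a functional assay on T98G cells (Homo sapiens) for inhibition, read by MTT assay, with a stated time of 72 h (a higher number here means a weaker inhibitor, a lower number a stronger inhibitor), compound 1 gives 87000 nM, the highest value of the set. Compound 2, `CC1(C)CC(NC(=O)NCc2ccccc2)c2cc(Cl)ccc2O1`, gives 15000 nM, and compound 3, `O=[N+]([O-])c1cccc(NC(=S)NC2CCOc3ccc(Cl)cc32)c1`, gives 10000 nM; both of these gaps to compound 1 lie beyond the usual scatter. The next compound, compound 4, `COc1ccccc1NC(=S)NC1CC(C)(C)Oc2ccc(Br)cc21`, shares every atom with compound 1 and differs only in how they are joined: 2-methoxyphenyl in place of 3-methoxyphenyl on an amide-type nitrogen. Among the measured compounds shown here, no measured pair shows what moving the methoxy group does here, so the step is expected to be small, in no clear direction, and likely within the scatter. Compound 4 is therefore estimated at 70000 nM, with a range of 25000 nM to 200000 nM, an expected step of a 1.2-fold lower number from compound 1 to compound 4 (0.09 log units; within the scatter).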

Compound 4, half-maximal inhibitory concentration: 42000 nM
For compound 4 the middle estimate is 1.7-fold (0.22 log units) above the measured one, and the stated range covers the measured number.
By their numbers in this assay, from the lowest: compounds 3 and 2 (each within the scatter of the next); then compound 4; then compound 1.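

In this assay, among the compounds shown here, 2-methoxyphenyl in place of 3-methoxyphenyl on an amide-type nitrogen gives a 2.1-fold lower number from compound 1 to compound 4 (0.32 log units; beyond the scatter) and is the first one-place comparison in the set. It shows that this position responds, modestly, to a rearrangement alone, with the same atoms in both compounds. Nothing on hand accounts for the shift.

The compounds shown leave open how an amine, a hydroxyl or a carboxylic acid in place of the methoxy group would read here. Also open, going by these compounds, is whether the same change would give a similar step on the core of compound 3.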